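Chlorophenyl shift carried onto the shorter-chain core

The compounds below may be only part of what the source reports. "The series", "measured", "known", "first", "only" and "open" are said of these compounds alone.

Compound 1 `CCCCCCn1cnc2c(Nc3ccc(Cl)cc3)nc(N[C@H]3CC[C@H](N)CC3)nc21` and compound 3 `CCCCn1cnc2c(Nc3ccc(Cl)cc3)nc(N[C@H]3CC[C@H](N)CC3)nc21` differ in the core by hydrogen in place of ethyl on a saturated chain carbon, four bonds along the chain from an aromatic nitrogen. In a functional assay on BT-474 cells (Homo sapiens) for inhibition, read by fluorescence, with a stated time of 72 h (on this read-out lower numbers stand for stronger inhibition of growth and higher numbers for weaker inhibition of growth), compound 1 gives 5500 nM and compound 3 gives 7300 nM, the step being a 1.3-fold higher number from compound 1 to compound 3 (0.12 log units; within the scatter). Compound 2 `CCCCCCn1cnc2c(Nc3cccc(Cl)c3)nc(N[C@H]3CC[C@H](N)CC3)nc21` is reached from compound 1 by 3-chlorophenyl in place of 4-chlorophenyl on a nitrogen on an aromatic ring, and in this assay compound 2 gives 5100 nM; the step is a 1.1-fold lower number from compound 1 to compound 2 (0.03 log units; within the scatter). Compound 4 `CCCCn1cnc2c(Nc3cccc(Cl)c3)nc(N[C@H]3CC[C@H](N)CC3)nc21` is reached from compound 3 by 3-chlorophenyl in place of 4-chlorophenyl on a nitrogen on an aromatic ring, the same change at the same place. Compound 4 is expected to give about 6800 nM in this assay, because the earlier step of a 1.1-fold lower number from compound 1 to compound 2 (0.03 log units; within the scatter) stayed within the scatter. The expected step is a 1.1-fold lower number from compound 3 to compound 4 (0.03 log units; within the scatter), resting on compound 3 at 7300 nM. For compound 4 the estimated range runs from 3000 nM to 15000 nM.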

Compound 4, concentration for 50% growth inhibition: 5100 nM
Estimate against measurement, compound 4: 1.3-fold (0.12 log units) above; low and high end bracket the measured number.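

In this assay, 3-chlorophenyl in place of 4-chlorophenyl gives a 1.4-fold lower number from compound 3 to compound 4 (0.16 log units; within the scatter), and this step agrees with the one on the core of compound 1: the same change on two cores in this assay, a 1.1-fold lower number (0.03 log units; within the scatter) from compound 1 to compound 2 and a 1.4-fold lower number (0.16 log units; within the scatter) from compound 3 to compound 4, 1.3-fold (0.12 log units) apart, within the scatter of two such steps

The chain change, read on the 3-chlorophenyl pair, gives no change at the digits printed from compound 2 to compound 4 (within the scatter), and it also agrees with its earlier counterpart: the same change on two cores in this assay, a 1.3-fold higher number (0.12 log units; within the scatter) from compound 1 to compound 3 and no change at the digits printed (within the scatter) from compound 2 to compound 4, 1.3-fold (0.12 log units) apart, within the scatter of two such steps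

Within the data shown here, all of these steps lie within the scatter, so the agreement shows only that neither change has a readable effect on either core; it does not show that a step of readable size would carry from one core to another.

Still open, on these data alone, is whether a methoxyphenyl or an unsubstituted phenyl in place of the chlorophenyl, or a longer chain than that of compound 1, would give a step beyond the scatter. As far as these compounds go, replacing the free amine with an amide is equally open.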